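A Triazole Aryl Swap Tested Against Liver Cells

The source may hold more compounds than are shown below. What is called first, only, known or untested is meant among the compounds shown, and "the series" means these compounds.

Compound 1 `Cc1ccccc1-n1nncc1CN1C(=O)C2(C(C#N)=C(N)Oc3c2c2nc4ccccc4nc2c2ccccc32)c2ccccc21` is the reference here. In an ADME assay on L02 cells (Homo sapiens) for antiproliferative activity, read by MTT assay, with a stated time of 48 h (a higher number here means a weaker inhibitor, a lower number a stronger inhibitor), compound 1 gives > 50000 nM, which is a limit of the assay rather than a number. Compound 2 `N#CC1=C(N)Oc2c(c3nc4ccccc4nc3c3ccccc23)C12C(=O)N(Cc1cnnn1-c1ccccc1Cl)c1ccccc12` carries chloro in place of methyl on an aromatic carbon; in this assay compound 2 gives > 50000 nM, again only a limit. Compound 3 `N#CC1=C(N)Oc2c(c3nc4ccccc4nc3c3ccccc23)C12C(=O)N(Cc1cnnn1-c1ccc(Br)cc1)c1ccccc12` carries 4-bromophenyl in place of 2-methylphenyl on an aromatic nitrogen; in this assay compound 3 gives > 50000 nM, also a limit. Among the compounds with values here, the steps a step that the two limits leave unreadable from compound 1 to compound 2, a step that the two limits leave unreadable from compound 1 to compound 3 and a step that the two limits leave unreadable from compound 2 to compound 3 therefore have no readable size, since the limit of > 50000 nM in this assay, at which 3 of the 3 values shown sit, is where every value so far sits.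

Compound 4 `N#CC1=C(N)Oc2c(c3nc4ccccc4nc3c3ccccc23)C12C(=O)N(Cc1cnnn1-c1cccc(Br)c1)c1ccccc12` has not yet been measured. It differs from compound 1 in one place: 3-bromophenyl in place of 2-methylphenyl on an aromatic nitrogen. The measured steps that bear on this change are those moving the aryl group on the triazole nitrogen, and none of them shows a number, so no step beyond the scatter can be read in either direction. Compound 4 is expected to sit at the same limit, estimated at 50000 nM with a range from 20000 nM to 120000 nM. The expected step from compound 1 is then a number no higher from compound 1 to compound 4 (the limit leaves the size open), most likely again unreadable.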

Compound 4, half-maximal inhibitory concentration: > 50000 nM
Compound 4 ended at the assay's limit; the forecaster's own chance of this, stated with the estimate: 85%; the middle value lies on the limit itself.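

In this assay compound 4 gives > 50000 nM, again a limit of the assay. The steps to compound 4 from compound 1, compound 2 and compound 3 therefore cannot be read, as all four compounds stand at the same limit: the limit of > 50000 nM in this assay, at which 4 of the 4 values shown sit.

As far as these compounds go, how far past that limit each compound lies, and whether the aryl groups on the triazole differ at all in this respect, stays open.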